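The source may hold more compounds than are shown below. What is called first, only, known or untested is meant among the compounds shown, and "the series" means these compounds.

In a functional assay on HeLa cells (Homo sapiens) for antiproliferative activity, read by MTT assay, with a stated time of 48 h (a higher number here means a weaker inhibitor, a lower number a stronger inhibitor), three compounds have been measured so far.
Compound 1 `Cn1cc(-c2cnc3ccc(NCC4CC4)nc3c2)cn1`: > 50000 nM, which is a limit of the assay rather than a number.
Compound 2 `Cn1cc(-c2cnc3ccc(NCc4ccc(F)cc4)nc3c2)cn1`: 46600 nM.
Compound 3 `Cn1cc(-c2cnc3ccnc(NCC4CC4)c3c2)cn1`: 7400 nM.

Compound 1 and compound 2 share one core. Compound 3 is built from the same atoms joined differently, and the difference between the two cores is not broken down here. Within the first core, the change from compound 1 to compound 2 is 4-fluorophenyl in place of cyclopropyl on a saturated chain carbon bound to a nitrogen on an aromatic ring. The measured result of that change is an at least 1.0-fold lower number from compound 1 to compound 2 (0.03 log units; that floor lies within the scatter), a floor that follows from the limit of > 50000 nM in this assay, at which 1 of the 3 values shown sits, so the true size of the step is not known. Compound 3 gives the lower of the two numbers available for comparison.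

Compound 4 `Cn1cc(-c2cnc3ccnc(NCc4ccc(F)cc4)c3c2)cn1` has not yet been measured. It carries the same change on the core of compound 3, namely (4-fluorophenyl in place of cyclopropyl on a saturated chain carbon bound to a nitrogen on an aromatic ring). Because the same change from compound 1 to compound 2 produced an at least 1.0-fold lower number from compound 1 to compound 2 (0.03 log units; that floor lies within the scatter) with only a limit as its starting point, the earlier pair gives no firm direction, and the expectation for compound 4 leans on compound 3 staying roughly where it is. For compound 4 the expected value in this assay is 6500 nM, with a range estimated from 2000 nM to 20000 nM. That estimate means an expected step of a 1.1-fold lower number from compound 3 to compound 4 (0.06 log units; within the scatter), small enough to sit within the usual scatter.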

Compound 4, half-maximal inhibitory concentration: 9200 nM
Estimate against measurement, compound 4: 1.4-fold (0.15 log units) below, and the stated range covers the measured number.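

In this assay, going from cyclopropylmethyl to 4-fluorobenzyl on the core of compound 3 gives a 1.2-fold higher number from compound 3 to compound 4 (0.09 log units; within the scatter), so on this core the two numbers cannot be told apart and the larger group, with its aromatic ring, shows no measurable consequence in this read-out. Set beside the step on the other core, this result does not show that the change carries over from one core to the other, nor does it show that the two cores respond differently: the same change on two cores in this assay, an at least 1.0-fold lower number (0.03 log units; that floor lies within the scatter) from compound 1 to compound 2 and a 1.2-fold higher number (0.09 log units; within the scatter) from compound 3 to compound 4; the limit leaves it open whether they differ. Compound 1 gives > 50000 nM, which is a limit and not a number, and the step on its core therefore has only a floor, with a single such value among those shown: the limit of > 50000 nM in this assay, at which 1 of the 4 values shown sits.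

The compounds shown place only cyclopropyl and 4-fluorophenyl on the saturated chain carbon, so it remains open how an amine, a carboxylic acid or a longer chain at that place would read in this assay. Also open, as far as these compounds go, is whether the change would give the same result on a core where both members of the pair yield a measured number rather than a limit.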